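Methoxy to ethoxy: notes toward compound 3

A few compounds are considered here, and "the series" means these few. Any claim that something is new, unique, unknown or untested is made for them only; others in the source may bear on it.

Measured so far in a functional assay for activation of Alpha-1D adrenergic receptor (Homo sapiens); on this read-out lower numbers stand for an effect already at smaller amounts and higher numbers for an effect only at larger amounts of compound:
Compound 1 `c1ccc(-c2cnoc2)c(NCC2=NCCN2)c1`: < 100000 nM
Compound 2 `CO/N=C(\C)c1ccccc1NCC1=NCCN1`: < 5020 nM

In this assay compound 1 gives < 100000 nM, which is a limit of the assay and not a number. Compound 2 likewise gives only a limit in this assay, < 5020 nM. The step that the two limits leave unreadable from compound 1 to compound 2 cannot be read, since both values sit at limits (the limit of < 100000 nM in this assay, at which 1 of the 2 values shown sits, (the limit of < 5020 nM in this assay, at which 1 of the 2 values shown sits)). Compound 2 thus stands at an assay limit, without an exact value among the numbers shown.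

Compound 3 `CCO/N=C(\C)c1ccccc1NCC1=NCCN1` differs from compound 2 by methyl in place of hydrogen on a saturated chain carbon bound to an oxygen on an unsaturated carbon. Among the compounds with values here, no measured step bears on this change; the single measured step is unreadable. The expected step that the limit leaves unreadable from compound 2 to compound 3 in this assay is therefore taken as small, with no direction beyond the scatter. Compound 3 is estimated at 2500 nM, within 300 nM to 20000 nM, and a limit alone is again plausible.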

Compound 3, half-maximal effective concentration: < 5020 nM
Compound 3 was reported as a limit (the forecaster's own chance of this, stated with the estimate: 50%); the middle value does not contradict the limit.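

In this assay compound 3 gives < 5020 nM, a limit of the assay and not a number. Within the data shown here, no step among compound 1, compound 2 and compound 3 can be read. The compounds shown leave open their exact values, and so whether methoxy to ethoxy shifts the read-out at all.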